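The source may hold more compounds than are shown below. What is called first, only, known or untested is meant among the compounds shown, and "the series" means these compounds.

Values in a toxicity assay on GES1 cells (Homo sapiens) for inhibition, read by MTT assay, with a stated time of 72 h; on this read-out higher numbers stand for weaker inhibition and lower numbers for stronger inhibition:
compound 1 `Cc1cc(N2CC[C@@H](C)[C@@H](N(C)c3ncnc4[nH]ccc34)C2)n2nc(SCc3ccc(F)cc3)nc2n1`: 12300 nM
compound 2 `Cc1cc(N2CC[C@@H](C)[C@@H](N(C)c3ncnc4[nH]ccc34)C2)n2nc(SCc3ccc(F)c(Cl)c3)nc2n1`: > 100000 nM, a limit of the assay and not a number

Compound 2 therefore has no numerical place in the series, and the record for it reads: the limit of > 100000 nM in this assay, at which 1 of the 2 values shown sits. The next compound is compound 3 `Cc1ccc(CSc2nc3nc(C)cc(N4CC[C@@H](C)[C@@H](N(C)c5ncnc6[nH]ccc56)C4)n3n2)cc1`, and the change to it is 4-methylphenyl in place of 3-chloro-4-fluorophenyl on a saturated chain carbon bound to a sulfur. In words, 4-methylphenyl stands in place of 3-chloro-4-fluorophenyl on a saturated chain carbon bound to a sulfur.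

Among the measured compounds shown here, one measured step bears on this: an at least 8.1-fold higher number from compound 1 to compound 2 (0.91 log units; beyond the scatter). That step came with chloro in place of hydrogen on an aromatic carbon, and compound 3 carries no chloro. In this respect compound 3 resembles compound 1 at 12300 nM. For the measured compounds named here, no measured step covers the 4-methylphenyl group itself, so the expectation stays wide.

A move back toward a lower number, meaning stronger inhibition, is expected, and the expected step is an at least 4.0-fold lower number from compound 2 to compound 3 (0.60 log units; beyond the scatter). The estimated value for compound 3 is 25000 nM, with an expected range of 7000 nM to 100000 nM.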

Compound 3, half-maximal inhibitory concentration: 82500 nM
Beside the measured number, compound 3's estimate is 3.3-fold (0.52 log units) below it; measured number inside the range.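

In this assay, the higher number no longer depends on chloro: a 6.7-fold higher number from compound 1 to compound 3 (0.83 log units; beyond the scatter), with methyl in place of fluoro on an aromatic carbon and no chloro present. Against compound 2 the comparison gives no order, since an at least 1.2-fold lower number from compound 2 to compound 3 (0.08 log units; that floor lies within the scatter) is only a floor within the scatter, and 4-methylphenyl and 3-chloro-4-fluorophenyl on a saturated chain carbon bound to a sulfur therefore cannot be ranked. Compound 2 remains a limit of the assay and not a number: the limit of > 100000 nM in this assay, at which 1 of the 3 values shown sits.

Across these three compounds, both changes from compound 1 raise the number, but that is a pattern of only two changes and one of them ends at a limit, so it does not show whether replacing fluoro generally raises the number or whether methyl is a particular case. As far as these compounds go, what a methoxy group, an amine or a carboxylic acid on that aromatic carbon would give stays open, as does whether any change to the sulfur link or the shared core moves the number in this assay.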